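This account rests on a few compounds, and the source may have more. Where it says the series, first, only, none or still open, it means among the compounds named here.

Series notes. In an ADME assay on HeLa cells (Homo sapiens) for cytotoxicity, read by crystal violet staining, with a stated time of 72 h (on this read-out lower numbers stand for higher toxicity in this test and higher numbers for lower toxicity in this test), compound 2 `Cc1cc(-c2noc(C(F)(F)F)n2)cc(C)c1OCCCc1cc(C(=O)N(C)C)no1` gives 13200 nM. Compound 1 `CNC(=O)c1cc(CCCOc2c(C)cc(-c3noc(C(F)(F)F)n3)cc2C)on1` reaches only a limit of this assay, > 100000 nM. The change from compound 2 to compound 1 is hydrogen in place of methyl on an amide-type nitrogen, and the step is an at least 7.5-fold higher number from compound 2 to compound 1 (0.87 log units; beyond the scatter); its size is open-ended because compound 1 sits at the limit of > 100000 nM in this assay, at which 1 of the 3 values shown sits. Compound 3 `CN(C)C(=O)c1cc(CCCOc2ccc(-c3noc(C(F)(F)F)n3)cc2C(F)(F)F)on1` gives 19200 nM in this assay; this value and that of compound 2 lie within the scatter, and the difference between the two cores is not broken down here. Compound 4 `CNC(=O)c1cc(CCCOc2ccc(-c3noc(C(F)(F)F)n3)cc2C(F)(F)F)on1` has not been measured. It differs from compound 3 by hydrogen in place of methyl on an amide-type nitrogen, the same change as the earlier one, with the place described in identical words. The expected step is a 7.3-fold higher number from compound 3 to compound 4 (0.86 log units; beyond the scatter), resting on an at least 7.5-fold higher number from compound 2 to compound 1 (0.87 log units; beyond the scatter). Compound 4 is therefore estimated at 140000 nM, with a fair chance that this assay again returns only its limit.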

Compound 4, half-maximal cytotoxic concentration: > 100000 nM
Compound 4 ended at the assay's limit; the forecaster's own chance of this, stated with the estimate: 65%; the middle value does not contradict the limit.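

In this assay, hydrogen in place of methyl on an amide-type nitrogen carries over to a second core, with the step reading an at least 5.2-fold higher number from compound 3 to compound 4 (0.71 log units; beyond the scatter). The direction is the same on both cores, but neither size is fixed: the same change on two cores in this assay, an at least 7.5-fold higher number (0.87 log units; beyond the scatter) from compound 2 to compound 1 and an at least 5.2-fold higher number (0.71 log units; beyond the scatter) from compound 3 to compound 4; the limit leaves it open whether they differ. Two cores show that the change travels within this small set, not how large it is on either core or whether it holds on other cores in the series.

Still open, as far as these compounds go, is how a primary amide, an N-ethyl amide or a carboxylic acid would read in place of the methylcarbamoyl group. Also open, from the compounds shown here alone, is whether the change holds on a core carrying chlorine or methoxy in place of trifluoromethyl.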